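The compounds below may be only part of what the source reports. "The series", "measured", "known", "first", "only" and "open" are said of these compounds alone.

Compound 1 `COc1ccc(C(=O)CCN2CCN(c3ccc(Cl)cc3)CC2)cc1` is the parent of the set. In an ADME assay on Vero cells (Chlorocebus sabaeus) for cytotoxicity, read by resazurin assay, with a stated time of 72 h (on this read-out higher numbers stand for weaker inhibition and lower numbers for stronger inhibition), compound 1 gives 300000 nM. Compound 2 `COc1ccc(C(=O)CCN2CCN(c3ccc([N+](=O)[O-])cc3)CC2)cc1` carries the change (nitro in place of chloro on an aromatic carbon); in this assay compound 2 gives 587000 nM, which makes the step of a 2.0-fold higher number from compound 1 to compound 2 (0.29 log units; within the scatter). Compound 3 `O=C(CCN1CCN(c2ccc(Cl)cc2)CC1)c1ccc(F)c(Br)c1` differs from compound 1 in the core, namely (3-bromo-4-fluorophenyl in place of 4-methoxyphenyl on a carbonyl carbon); in this assay compound 3 gives 206000 nM, and the step is a 1.5-fold lower number from compound 1 to compound 3 (0.16 log units; within the scatter). Compound 4 `O=C(CCN1CCN(c2ccc([N+](=O)[O-])cc2)CC1)c1ccc(F)c(Br)c1` is not yet measured. Among the measured compounds shown here, it differs from compound 3 by nitro in place of chloro on an aromatic carbon, which is the same change as the one between compound 1 and compound 2, now made on the core of compound 3; the place of the change is the same in both pairs. The measured instance of this change gave a 2.0-fold higher number from compound 1 to compound 2 (0.29 log units; within the scatter). The expectation for compound 4 rests on that single instance and on compound 3 at 206000 nM. For compound 4 in this assay a step of a 1.9-fold higher number from compound 3 to compound 4 (0.29 log units; within the scatter) is expected. Compound 4 is estimated at 400000 nM, with a range from 200000 nM to 800000 nM.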

Compound 4, half-maximal inhibitory concentration: 256000 nM
For compound 4 the middle estimate is 1.6-fold (0.19 log units) above the measured one; the range from low to high includes it.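

In this assay, nitro in place of chloro gives a 1.2-fold higher number from compound 3 to compound 4 (0.09 log units; within the scatter), and this result agrees with the step on the core of compound 1: the same change on two cores in this assay, a 2.0-fold higher number (0.29 log units; within the scatter) from compound 1 to compound 2 and a 1.2-fold higher number (0.09 log units; within the scatter) from compound 3 to compound 4, 1.6-fold (0.20 log units) apart, within the scatter of two such steps. The exchange of 4-methoxyphenyl for 3-bromo-4-fluorophenyl, read with nitro in place, gives a 2.3-fold lower number from compound 2 to compound 4 (0.36 log units; beyond the scatter), and the two readings of this change also agree: the same change on two cores in this assay, a 1.5-fold lower number (0.16 log units; within the scatter) from compound 1 to compound 3 and a 2.3-fold lower number (0.36 log units; beyond the scatter) from compound 2 to compound 4, 1.6-fold (0.20 log units) apart, within the scatter of two such steps. The four compounds therefore show that both changes carry between these two cores within the scatter, but this is a single comparison for each change, and with the nitro steps within the scatter on both cores, it establishes neither a real effect of that change nor any transfer beyond these compounds.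

The compounds shown leave open whether an amine or a carboxylic acid in place of chloro would follow the same course on both cores. They also leave open whether the steps would agree with a longer chain on the carbonyl carbon of the shared core.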